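Swapping hydroxy for methyl in a weakly cytotoxic series

A few compounds are considered here, and "the series" means these few. Any claim that something is new, unique, unknown or untested is made for them only; others in the source may bear on it.

- Compound 1 `Fc1cccc(-c2nc(Nc3ccccc3F)c3cc(F)ccc3n2)c1` gives > 50000 nM as a limit
- Compound 2 `Fc1cccc(-c2nc(Nc3ccc(Cl)cc3)c3cc(F)ccc3n2)c1` gives 32700 nM as a number
- Compound 3 `Oc1ccc(Nc2nc(-c3cccc(F)c3)nc3ccc(F)cc23)cc1` gives > 50000 nM as a limit

All three values come from a functional assay on U-937 cells (Homo sapiens) for cytotoxicity, read by MTT assay, with a stated time of 48 h (a lower number here means a stronger inhibitor, a higher number a weaker inhibitor), and only compound 2 has a true number there. Compound 3 stands at the limit of > 50000 nM in this assay, at which 2 of the 3 values shown sit, and so has no number of its own. Compound 4 `Cc1ccc(Nc2nc(-c3cccc(F)c3)nc3ccc(F)cc23)cc1` carries methyl in place of hydroxy on an aromatic carbon, para to a large group methyl in place of hydroxy on an aromatic carbon here. The closest measured change is an at least 1.5-fold higher number from compound 2 to compound 3 (0.18 log units; that floor lies within the scatter) with hydroxy in place of chloro. That step and an at least 1.5-fold lower number from compound 1 to compound 2 (0.18 log units; that floor lies within the scatter) both have floors within the scatter. A small step toward a lower number is therefore expected, namely an at least 1.3-fold lower number from compound 3 to compound 4 (0.11 log units; that floor lies within the scatter) as estimated. Compound 4 is estimated at 38000 nM with a range of 18000 nM to 60000 nM expected.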

Compound 4, half-maximal inhibitory concentration: > 50000 nM
Compound 4 ended at the assay's limit (the forecaster's own chance of this, stated with the estimate: 45%); at least 1.3-fold (0.11 log units) between middle value and limit.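

In this assay, methyl at this position, like hydroxy, leaves the compound at a limit and not at a number: the limit of > 50000 nM in this assay, at which 3 of the 4 values shown sit. The steps to compound 4 from compound 1 and from compound 3 join two limits and cannot be read. Within the data shown here, the one readable comparison is an at least 1.5-fold higher number from compound 2 to compound 4 (0.18 log units; that floor lies within the scatter), with methyl in place of chloro, and compound 2 keeps the only true number in the set.

Going by these compounds, what an amine or a carboxylic acid would give at this position remains open. So does where compound 4 and compound 3 lie beyond the limit.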